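This account rests on a few compounds, and the source may have more. Where it says the series, first, only, none or still open, it means among the compounds named here.

Two compounds sharing one core have numbers in a physicochemical assay for solubility; a higher number here means a more soluble compound, a lower number a less soluble compound. Compound 1 (`CC(C)(C)OC(=O)N1CCC[C@@H]1C(=O)N1CCC(NS(=O)(=O)c2cc(S(=O)(=O)c3ccccc3)ccc2C(F)(F)F)CC1`) gives 25000 nM. Compound 2 (`O=C([C@@H]1CCCN1C(=O)N1CCOCC1)N1CCC(NS(=O)(=O)c2cc(S(=O)(=O)c3ccccc3)ccc2C(F)(F)F)CC1`) gives 50000 nM, which lies within the scatter of the value for compound 1, so the two cannot be told apart on this read-out. Compound 3 (`CC(C)(C)CCN1CCC[C@H]1C(=O)N1CCC(NS(=O)(=O)c2cc(S(=O)(=O)c3ccccc3)ccc2C(F)(F)F)CC1`) has not yet been measured. It differs from compound 2 on an amine nitrogen in a ring, where 3,3-dimethylbutyl stands in place of (morpholin-4-yl)carbonyl: 3,3-dimethylbutyl in place of (morpholin-4-yl)carbonyl on an amine nitrogen in a ring. Going by the values given here, no measured pair of compounds differs in one place only, so the data offer no direct precedent for this exchange, and any expectation remains tentative. Starting from compound 2 at 50000 nM, a modest downward step in this assay is expected, only slightly beyond the scatter. The estimated step is a 2.5-fold lower number from compound 2 to compound 3 (0.40 log units; beyond the scatter). Compound 3 is expected to give 20000 nM, with an estimated range from 5000 nM to 60000 nM.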

Compound 3, solubility: 12500 nM
Estimate against measurement, compound 3: 1.6-fold (0.20 log units) above; low and high end bracket the measured number.
By their numbers in this assay, from the lowest: compounds 3, 1 and 2 (each within the scatter of the next, the first and the last beyond it).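

Going by these compounds alone, on an amine nitrogen in a ring, 3,3-dimethylbutyl in place of (morpholin-4-yl)carbonyl gives the first step in this assay that is printed as beyond the scatter (a 4.0-fold lower number from compound 2 to compound 3 (0.60 log units; beyond the scatter)), so the group on this nitrogen can shift the read-out. The exchange of 1-(tert-butoxycarbonyl)pyrrolidin-2-yl for 1-(3,3-dimethylbutyl)pyrrolidin-2-yl on a carbonyl carbon, by contrast, stays within the scatter (a 2.0-fold lower number from compound 1 to compound 3 (0.30 log units; within the scatter)), so compound 1 and compound 3 cannot be told apart in this assay and only the exchange starting from compound 2 registers as a real step. Nothing measured here explains either step.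

The step from the (morpholin-4-yl)carbonyl group removes a ring, a carbonyl and the hetero atoms in a single exchange, and these compounds cannot separate those parts, which a (morpholin-4-yl)ethyl chain on the same nitrogen could begin to do. Going by these compounds, it also remains open how a shorter alkyl chain, a chain bearing a carboxylic acid or a chain bearing an amine would read in this assay at this position.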